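The source may report more compounds than this note shows. Statements on the series, on what has been measured and on what is new or still open speak of the compounds shown alone.

Compound 3, with the structure `N#CC1=C(NCC(=O)N2CCCC2)N(c2ccccc2)C(=O)N2CCCCC(N3CCCC3)C12`, was tested in a functional assay on the whole organism (strain albino) for inhibition, with Rattus norvegicus as the target, read by paw edema, with a stated time of 1 h, at a dose of 20 mmol/kg by the intraperitoneal route (a higher number here means more inhibition at the dose given (going by the name of the read-out), a lower number less inhibition), and gave 40.1%. Among the three measured compounds it sits second highest: compound 1, of structure `N#CC1=C(NCC(=O)N2CCOCC2)N(c2ccccc2)C(=O)N2CCCCC(N3CCCC3)C12`, gave 43.9%, and the gap a number 3.8 percentage points lower from compound 1 to compound 3 (within the scatter) lies within the scatter. Compound 2, of structure `N#CC1=C(/N=C/Nc2ccc([N+](=O)[O-])cc2)N(c2ccccc2)C(=O)N2CCCCC(N3CCCC3)C12`, gave 32.1%, and the gap a number 8 percentage points higher from compound 2 to compound 3 (within the scatter) also lies within the scatter, so the three measured compounds cannot be ranked against each other with confidence.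

Compound 4, of structure `CCOC(=O)C(=O)NC1=C(C#N)C2C(N3CCCC3)CCCCN2C(=O)N1c1ccccc1`, has not yet been measured. It differs from compound 3 at the amine nitrogen: (ethoxycarbonyl)carbonyl in place of ((pyrrolidin-1-yl)carbonyl)methyl on an amine nitrogen. Among the compounds with values here, two measured steps bear on this. The step of a number 3.8 percentage points lower from compound 1 to compound 3 (within the scatter) shows that exchanging one ring partner of the amide carbonyl for another changes little. Within the data shown here, the step of a number 11.8 percentage points lower from compound 1 to compound 2 (beyond the scatter), a more thorough rebuilding of the group on the double-bonded ring carbon, was the only step beyond the scatter, and it went downward. The change to compound 4 is likewise a more thorough rebuilding, so a modest downward step is expected, with the estimate a number 3.1 percentage points lower from compound 3 to compound 4 (within the scatter). For compound 4 a value of about 37% is expected, with a range from 24% to 50%.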

Compound 4, a percentage reported as inhibition, in the whole organism at one dose (the size of the read-out at that dose, not a potency): 71.2%
Beside the measured number, compound 4's estimate is 34.2 percentage points below it; measured number outside the range, above it.
By their numbers in this assay, from the lowest: compounds 2, 3 and 1 (each within the scatter of the next, the first and the last beyond it); then compound 4.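

At the amine nitrogen on the double-bonded ring carbon, the group carried there proves to matter a great deal in this assay, whereas the earlier exchange of ring partners on the amide carbonyl had moved the number only within the scatter. Putting (ethoxycarbonyl)carbonyl in place of ((pyrrolidin-1-yl)carbonyl)methyl gives a step (a number 31.1 percentage points higher from compound 3 to compound 4 (beyond the scatter)), and putting it in place of ((morpholin-4-yl)carbonyl)methyl gives a step of the same direction (a number 27.3 percentage points higher from compound 1 to compound 4 (beyond the scatter)), so the rise holds against both amides; the step from the rebuilt group of the nitrophenyl-bearing compound (a number 39.1 percentage points higher from compound 2 to compound 4 (beyond the scatter)) points the same way, and compound 4 now stands above the other three by more than the scatter. Nothing measured here accounts for this rise.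

The compounds shown leave open which part of the entering group goes with the higher number, the ethyl ester end or the carbonyl attached to the nitrogen. As far as these compounds go, a free carboxylic acid, a methyl ester or a plain acetyl on the same nitrogen would separate these parts, and whether the rise persists at other doses or times also remains open.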